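Same Methyl Step on Two Related Ring Cores

The source may hold more compounds than are shown below. What is called first, only, known or untested is meant among the compounds shown, and "the series" means these compounds.

Compound 1 `CCCS(=O)(=O)N1CCN(C(C)=O)C1` and compound 3 `CCCS(=O)(=O)N1CCCN(C(C)=O)C1` both carry a propylsulfonyl group and an acetyl group on a small saturated ring; the difference between the two cores is not broken down here. In a functional assay on the whole organism with Mus musculus as the target (on this read-out higher numbers stand for an effect only at larger amounts of compound and lower numbers for an effect already at smaller amounts), compound 1 gives 10 mg/kg. In this assay compound 3 gives 1 mg/kg, the lower of the two numbers measured. Compound 2 `CCCS(=O)(=O)N1CCN(C(=O)CC)C1` differs from compound 1 by methyl in place of hydrogen on a saturated chain carbon bound to a carbonyl carbon. For compound 2 the assay reports only a limit, > 10 mg/kg. The step of a number no lower from compound 1 to compound 2 (the limit leaves the size open) can therefore not be sized, as shown by the limit of > 10 mg/kg in this assay, at which 1 of the 3 values shown sits. Compound 4 `CCCS(=O)(=O)N1CCCN(C(=O)CC)C1` carries the same change on compound 3: methyl in place of hydrogen on a saturated chain carbon bound to a carbonyl carbon. Compound 4 is expected to show the step of a 3.0-fold higher number from compound 3 to compound 4 (0.48 log units; beyond the scatter) in this assay, because a number no lower from compound 1 to compound 2 (the limit leaves the size open) ran toward a number no lower and the limit leaves its size open. Compound 4 is thus expected to need about 3 mg/kg, between 1 mg/kg and 10 mg/kg.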

Compound 4, minimum effective dose: > 10 mg/kg
Compound 4 was reported as a limit (the forecaster's own chance of this, stated with the estimate: 20%); middle value at least 3.3-fold (0.52 log units) away from the limit.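

On the core of compound 3, methyl in place of hydrogen on a saturated chain carbon bound to a carbonyl carbon gives an at least 10-fold higher number from compound 3 to compound 4 (1.00 log units; beyond the scatter) in this assay. On both cores the change gives no lower number, so its direction carries from one core to the other, but its size on the first core cannot be read and the two steps cannot be compared in size: the same change on two cores in this assay, a number no lower (the limit leaves the size open) from compound 1 to compound 2 and an at least 10-fold higher number (1.00 log units; beyond the scatter) from compound 3 to compound 4; the limit leaves it open whether they differ. On these data alone, compound 2 and compound 4 each sit at a limit of the assay rather than at a number, so how far the change reaches on either core stays unknown: the limit of > 10 mg/kg in this assay, at which 2 of the 4 values shown sit.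

The compounds shown leave open how either core would respond to a longer chain on the carbonyl, such as butanoyl. They also leave open whether an amine or a carboxylic acid on that chain would bring the number back down on the core of compound 3.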